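Methyl in Place of Ethoxy on a Carbonyl Carbon

The source may hold more compounds than are shown below. What is called first, only, known or untested is meant among the compounds shown, and "the series" means these compounds.

Compound 1 `C=C(C)[C@@H]1CC=C(Cn2cc(COc3cccc(C4NC(=O)NC(C)=C4C(=O)OCC)c3)nn2)CC1` and compound 3 `C=C(C)[C@@H]1CC=C(Cn2cc(COc3cccc(C4NC(=O)NC(C)=C4C(C)=O)c3)nn2)CC1` share a core and differ only by methyl in place of ethoxy on a carbonyl carbon. In a functional assay on NCI/ADR-RES cells (Homo sapiens) for inhibition, read by sulforhodamine B assay, with a stated time of 48 h (a higher number here means a weaker inhibitor of growth, a lower number a stronger inhibitor of growth), compound 1 gives no number, only the limit > 100000 nM. Compound 3 likewise gives only the limit > 100000 nM. The step that the two limits leave unreadable from compound 1 to compound 3 cannot be sized because both values sit at the limit of > 100000 nM in this assay, at which 3 of the 3 values shown sit.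

Compound 2 `C=C(C)[C@@H]1CC=C(Cn2cc(COc3ccccc3C3NC(=O)NC(C)=C3C(=O)OCC)nn2)CC1` is built from the same atoms as compound 1, joined differently; the difference between the two cores is not broken down here. In this assay compound 2 gives only the limit > 100000 nM. Compound 4 `C=C(C)[C@@H]1CC=C(Cn2cc(COc3ccccc3C3NC(=O)NC(C)=C3C(C)=O)nn2)CC1`, not yet measured, differs from compound 2 by methyl in place of ethoxy on a carbonyl carbon, the same change as between compound 1 and compound 3.

The step from compound 2 to compound 4 is expected to be about a number no higher from compound 2 to compound 4 (the limit leaves the size open). This expectation rests on compound 2, whose value > 100000 nM is a limit, and on the unreadable step that the two limits leave unreadable from compound 1 to compound 3. Compound 4 is therefore expected to give 100000 nM, most likely reported again only as a limit.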

Compound 4, concentration for total growth inhibition: > 100000 nM
Compound 4 was reported as a limit (the forecaster's own chance of this, stated with the estimate: 85%); the middle value sits exactly at the limit.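

No step can be read from compound 2 to compound 4, because both values are limits of the assay and not numbers: the limit of > 100000 nM in this assay, at which 4 of the 4 values shown sit. Whether ethoxycarbonyl to acetyl changes growth inhibition in this assay at all stays open for the compounds shown.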